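Hydrazide series: aryl swap on the cyclohexyl carbon

A few compounds are considered here, and "the series" means these few. Any claim that something is new, unique, unknown or untested is made for them only; others in the source may bear on it.

Measured so far:
compound 1 `Cc1ccccc1NNC(=O)CCC(C)C` — 148 nM
compound 2 `COc1ccc(C2(C(=O)NNc3cccc4ncccc34)CCCCC2)cc1` — 52.5 nM

In an in vitro functional assay on 1321-N1 cells for antagonist activity at P2X purinoceptor 7 (Homo sapiens), read by FLIPR and calcium flux (a higher number here means a weaker inhibitor, a lower number a stronger inhibitor), compound 2 gives 52.5 nM, the lower of the two numbers recorded. Compound 1, with 148 nM, sits higher by a gap beyond the scatter; the two structures differ in several places at once, so no single step can be read from them.

Compound 3 `O=C(NNc1cccc2ncccc12)C1(c2ccccc2F)CCCCC1` is the next candidate in this assay. Relative to compound 2 the change is 2-fluorophenyl in place of 4-methoxyphenyl on a saturated ring carbon; the rest of compound 2 is kept. Among the measured compounds shown here, no measured pair shows what such a swap does here, so the step is expected to be modest and could fall either side of compound 2 within the scatter, with a slight lean toward a higher number.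

The step expected from compound 2 to compound 3 is a 1.4-fold higher number from compound 2 to compound 3 (0.15 log units; within the scatter). Compound 3 is estimated at 75 nM, within a range from 25 nM to 250 nM.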

Compound 3, half-maximal inhibitory concentration: 191 nM
Estimate against measurement, compound 3: 2.5-fold (0.41 log units) below; low and high end bracket the measured number.
By their numbers in this assay, from the lowest: compound 2; then compounds 1 and 3 (each within the scatter of the next).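

In this assay, among the compounds shown here, putting 2-fluorophenyl in place of 4-methoxyphenyl on a saturated ring carbon gives a 3.6-fold higher number from compound 2 to compound 3 (0.56 log units; beyond the scatter) and provides the first single-place step. The aryl group on this ring carbon is therefore not interchangeable: this swap moves the number beyond the scatter, and compound 2, with 4-methoxyphenyl, holds the lower number of the pair. Nothing on hand bears on why the number moves.

This one step changes both the group on the phenyl ring and its location on that ring, so the two changes cannot be separated; 4-fluorophenyl and 2-methoxyphenyl on the same carbon would split them. Also open, from the compounds shown here alone, is how an unsubstituted phenyl would stand against compound 2 and compound 3 at this position.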